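Adding an amino group to a weak cytotoxic compound

The source may report more compounds than this note shows. Statements on the series, on what has been measured and on what is new or still open speak of the compounds shown alone.

Values from a functional assay on MCF7 cells (Homo sapiens) for cytotoxicity, read by MTT assay, with stated times of 6 h and 48 h (on this read-out higher numbers stand for weaker inhibition and lower numbers for stronger inhibition), follow
Compound 1 (`Cn1c(/C=C/C(=O)c2ccccc2)cc(Br)c1Br`) at 35400 nM
Compound 2 (`Cn1c(/C=C/C(=O)c2ccc(O)cc2)cc(Br)c1Br`) at 3120 nM

Compound 1 has the higher of the two numbers, which makes it the weaker inhibitor of the pair, and compound 2 is its nearest neighbour. The unmeasured compound 3 (`Cn1c(/C=C/C(=O)c2cccc(N)c2)cc(Br)c1Br`) carries amino in place of hydrogen on an aromatic carbon, meta to a large group (amino in place of hydrogen on an aromatic carbon). Among the measured compounds shown here, only one measured step bears on this change. It is a large step for hydroxy in place of hydrogen on an aromatic carbon (an 11-fold lower number from compound 1 to compound 2 (1.05 log units; beyond the scatter)). Hydroxy is a different group from amino and no amino compound has been measured, so a lower number is expected in this assay but a smaller step seems likely. The expected step is a 3.9-fold lower number from compound 1 to compound 3 (0.59 log units; beyond the scatter) in this estimate. For compound 3 the estimated value is 9000 nM with an expected range from 2500 nM to 30000 nM around it.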

Compound 3, half-maximal inhibitory concentration: 12400 nM
Compound 3: the middle estimate sits 1.4-fold (0.14 log units) below what was measured, within the range that was stated.
By their numbers in this assay, from the lowest: compound 2; then compound 3; then compound 1.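

In this assay, amino in place of hydrogen on an aromatic carbon, meta to a large group, gives a 2.9-fold lower number from compound 1 to compound 3 (0.46 log units; beyond the scatter) and so lowers the number beyond the scatter. Among the compounds shown here, this shows that hydroxy is not the only group on this ring of compound 1 whose arrival is followed by a lower number, and that a group can do so from this place. Compound 2 and compound 3 differ in more than one place, so an 11-fold lower number from compound 1 to compound 2 (1.05 log units; beyond the scatter) cannot be set against the amino step as a measure of one change, and nothing available explains the size of the amino step. As far as these compounds go, it remains open whether hydroxy at this same place would match amino. From the compounds shown here alone, it also remains open whether a dimethylamino or acetamido group there would lower the number further or give some of the step back.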